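Styryl ring substituents in a bile acid receptor ligand series

This account rests on a few compounds, and the source may have more. Where it says the series, first, only, none or still open, it means among the compounds named here.

Measured compounds:
compound 1, `COC(=O)/C=C/c1cccc(N(Cc2ccc(/C=C/c3c(Cl)cccc3Cl)cc2)C(=O)C(C)C)c1`, 195 nM
compound 2, `COC(=O)/C=C/c1cccc(N(Cc2ccc(/C=C/c3c(F)cccc3F)cc2)C(=O)C(C)C)c1`, 108 nM

In an assay on isolated protein with Bile acid receptor (Homo sapiens) as the target (a lower number here means that less compound is needed, a higher number that more compound is needed for the effect), compound 1 gives 195 nM and compound 2 gives 108 nM. Compound 2 has the smaller of the two numbers shown, but the step of a 1.8-fold lower number from compound 1 to compound 2 (0.26 log units; within the scatter) lies within the scatter, so the two cannot be told apart. Compound 3 `COC(=O)/C=C/c1cccc(N(Cc2ccc(/C=C/c3c(C)cc(C)cc3C)cc2)C(=O)C(C)C)c1` differs from compound 2 by 2,4,6-trimethylphenyl in place of 2,6-difluorophenyl on a double-bonded chain carbon bound to a double-bonded chain carbon. Going by the values given here, the only step bearing on this place, that from compound 1 to compound 2, was within the scatter, so no step beyond the scatter is expected in this assay for compound 3. Compound 3 is therefore estimated at 150 nM, with a range from 50 nM to 450 nM. The expected step is a 1.4-fold higher number from compound 2 to compound 3 (0.14 log units; within the scatter).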

Compound 3, half-maximal effective concentration: 149 nM
Estimate against measurement, compound 3: 1.0-fold (0.00 log units) above; measured number inside the range.
By their numbers in this assay, from the lowest: compounds 2, 3 and 1 (each within the scatter of the next).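

Swapping in the all-carbon 2,4,6-trimethylphenyl gives a 1.4-fold higher number from compound 2 to compound 3 (0.14 log units; within the scatter) in this assay, and the comparison with 2,6-dichlorophenyl gives a 1.3-fold lower number from compound 1 to compound 3 (0.12 log units; within the scatter). Three different aryl groups at this place, one with fluorine, one with chlorine and one with only carbon, therefore cannot be told apart in this assay. Nothing available explains this result. From the compounds shown here alone, whether a phenyl ring carrying an amine or a carboxylic acid at this place would give a step beyond the scatter remains open.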